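The source may hold more compounds than are shown below. What is called first, only, known or untested is meant among the compounds shown, and "the series" means these compounds.

Measured so far in an assay on isolated protein for inhibition of alpha-ketoglutarate-dependent dioxygenase alkB homolog 3 (Homo sapiens), read by polymerase chain reaction, with a stated time of 1 h; a lower number here means a stronger inhibitor, a higher number a weaker inhibitor:
compound 1 `Cc1[nH]n(-c2nc3cc(-c4ccccc4)ccc3[nH]2)c(=O)c1Cc1ccccc1` gives 810 nM
compound 2 `Cc1[nH]n(-c2nc3cc(Cl)ccc3[nH]2)c(=O)c1Cc1ccccc1` gives 4500 nM

For the measured compounds named here, compound 2 stands at the highest of the two numbers in this assay; its nearest neighbour is compound 1, and the single measured step, a 5.6-fold higher number from compound 1 to compound 2 (0.74 log units; beyond the scatter), is the only one that bears on the shared core. Compound 3 `Cc1ccc2[nH]c(-n3[nH]c(C)c(Cc4ccccc4)c3=O)nc2c1` arises from compound 2 by methyl in place of chloro on an aromatic carbon. Going by the values given here, that step exchanges one small group for another, and the one measured step concerns a different exchange, so a change of no more than the scatter is expected, a 1.1-fold higher number from compound 2 to compound 3 (0.05 log units; within the scatter). Compound 3 is therefore estimated at 5000 nM in this assay, within 2000 nM to 14000 nM.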

Compound 3, half-maximal inhibitory concentration: 670 nM
Beside the measured number, compound 3's estimate is 7.5-fold (0.87 log units) above it; the whole stated range lies above it.
By their numbers in this assay, from the lowest: compounds 3 and 1 (each within the scatter of the next); then compound 2.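

In this assay, this aromatic carbon proves sensitive even to an exchange of one heavy atom for one heavy atom: methyl in place of chloro gives a 6.7-fold lower number from compound 2 to compound 3 (0.83 log units; beyond the scatter). Methyl in place of phenyl gives a 1.2-fold lower number from compound 1 to compound 3 (0.08 log units; within the scatter), so among these three compounds a ring at this position is not required for the lower numbers, and chloro alone stands apart. No measurement offered here explains the difference between chloro and methyl.

From the compounds shown here alone, it remains open whether an amine, a methoxy group or a longer chain such as propyl would track methyl and phenyl or chloro at this position.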